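A few compounds are considered here, and "the series" means these few. Any claim that something is new, unique, unknown or untested is made for them only; others in the source may bear on it.

Measured compounds:
compound 1, `CC(C)OC(=O)N1CCC(O[C@H]2CC[C@H](Oc3ccc(S(C)(=O)=O)nc3)CC2)CC1`, in a functional assay on isolated protein for agonist activity at Glucose-dependent insulinotropic receptor (Homo sapiens), read by HTRF and cAMP accumulation; a lower number here means that less compound is needed, a higher number that more compound is needed for the effect: 13 nM
compound 2, `CC(C)OC(=O)N1CCC(O[C@H]2CC[C@H](Oc3cnc(S(C)(=O)=O)cn3)CC2)CC1`, in this assay: 13.7 nM

Of the compounds shown here, two have been measured, and they sit together. Compound 2 has the higher of the two numbers, but the step of a 1.1-fold higher number from compound 1 to compound 2 (0.02 log units; within the scatter) is within the scatter, so the two values show no real separation; compound 1 is its nearest neighbour. That one measured step swaps one aryl group for another on the ether oxygen of the saturated ring and leaves the carbamate end untouched.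

Compound 3, `CS(=O)(=O)c1cnc(O[C@H]2CC[C@H](OC3CCN(C(=O)OC4CCOC4)CC3)CC2)cn1`, is not yet measured. It differs from compound 2 at the other end of the molecule: oxolan-3-yl in place of isopropyl on an oxygen next to a carbonyl group. Going by the values given here, no measured step touches this carbamate ester, so nothing in the data speaks directly to the change; the only step on record, from compound 1 to compound 2, concerns a different part and was within the scatter. With no evidence in either direction, compound 3 is expected to stay close to compound 2, with a step of a 1.2-fold higher number from compound 2 to compound 3 (0.07 log units; within the scatter) that need not exceed the scatter. The estimate for compound 3 in this assay is 16 nM, ranging from 5 nM to 50 nM.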

Compound 3, half-maximal effective concentration: 427 nM
Estimate against measurement, compound 3: 27-fold (1.43 log units) below, outside the stated range (above it).
By their numbers in this assay, from the lowest: compounds 1 and 2 (each within the scatter of the next); then compound 3.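

Of the two places changed so far, only the carbamate ester has moved the number beyond the scatter: in this assay, oxolan-3-yl in place of isopropyl on an oxygen next to a carbonyl group gives a 31-fold higher number from compound 2 to compound 3 (1.49 log units; beyond the scatter), whereas the aryl exchange at the other end of the molecule gave a 1.1-fold higher number from compound 1 to compound 2 (0.02 log units; within the scatter). This position therefore does not accept every change of group, and one substitution here outweighs anything the earlier pair showed. The entering group differs from isopropyl in several ways at once, with more heavy atoms, a five-membered non-aromatic ring and a hydrogen-bond acceptor, and no measurement on hand says which of these matters.

The compounds shown leave open whether the ring or its oxygen accounts for the step, a question that a cyclopentyl group, with the ring but not the oxygen, or a tert-butyl group, with neither, would help to settle. They also leave open whether oxolan-3-yl would have the same effect with the 6-(methylsulfonyl)pyridin-3-yl group of compound 1 at the other end.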